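Adding 1-methylpiperidin-4-yl to compound 1

The compounds below may be only part of what the source reports. "The series", "measured", "known", "first", "only" and "open" are said of these compounds alone.

In a physicochemical assay for solubility, read by HPLC, in phosphate buffer, measured as kinetic solubility, with a stated time of 1 h, at pH 7.4, tested at 250 uM (a higher number here means a more soluble compound, a lower number a less soluble compound), compound 1 (`O=C(NCCCCc1ccccc1)n1cc(-c2ccc(F)cc2)oc1=O`) gives < 1000 nM, which is a limit and not a number. Compound 2 (`COc1cccc(-c2cn(C(=O)NCCCCc3ccccc3)c(=O)o2)c1`) gives < 1000 nM, also a limit. Compound 3 (`O=C(NCCCCc1ccccc1)n1cc(-c2cnccn2)oc1=O`) gives < 1000 nM, again a limit. The record thus holds the limit of < 1000 nM in this assay, at which 3 of the 3 values shown sit, and nothing finer. Going by the values given here, compound 4 (`CN1CCC(c2cc(F)ccc2-c2cn(C(=O)NCCCCc3ccccc3)c(=O)o2)CC1`) departs from compound 1 by 1-methylpiperidin-4-yl in place of hydrogen on an aromatic carbon, a kind of change that no measured compound shows. The nearest steps are a step that the two limits leave unreadable from compound 1 to compound 2 and a step that the two limits leave unreadable from compound 1 to compound 3, and neither gives a size to carry over. A modest upward move is therefore expected only loosely, as an at least 3.0-fold higher number from compound 1 to compound 4 (0.47 log units; beyond the scatter). In this assay the estimate for compound 4 is 3000 nM, with an expected range from 500 nM to 30000 nM.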

Compound 4, solubility: 60000 nM
Compound 4: the middle estimate sits 20-fold (1.30 log units) below what was measured; measured number above the stated range.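

In this assay, 1-methylpiperidin-4-yl in place of hydrogen gives an at least 60-fold higher number from compound 1 to compound 4 (1.77 log units; beyond the scatter), the only readable step among the compounds shown. It shows that this position on the aromatic ring, ortho to a large group, accepts a change that carries a compound clear of the limit. Compound 4 alone stands apart from that limit: the limit of < 1000 nM in this assay, at which 3 of the 4 values shown sit.

The compounds shown leave open whether a piperidin-4-yl without the methyl, a morpholine or an open-chain amine would give a similar step here. They also leave open whether 1-methylpiperidin-4-yl would do the same on another carbon of that ring.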